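Solubility of three aminoquinoline ethers and an alkyl analogue

This account rests on a few compounds, and the source may have more. Where it says the series, first, only, none or still open, it means among the compounds named here.

Compound 1 `CN(C)c1cccc(Oc2ccc3c(NCCCNCc4ccco4)ccnc3c2)c1`: 14500 nM
Compound 2 `COc1ccc(F)cc1CNCCCNc1ccnc2cc(Oc3cccc(N(C)C)c3)ccc12`: 14500 nM
Compound 3 `COc1cccc(CNCCCNc2ccnc3cc(Oc4cccc(N(C)C)c4)ccc23)c1O`: 14500 nM

In a physicochemical assay for solubility, with a stated time of 18 h, at pH 7.4 (on this read-out higher numbers stand for higher solubility and lower numbers for lower solubility), compound 1 stands level with compounds 2 and 3. The steps of no change at the digits printed from compound 1 to compound 2 (within the scatter) and no change at the digits printed from compound 1 to compound 3 (within the scatter) both replaced the group on the saturated chain carbon bound to an amine nitrogen, and no change at the digits printed from compound 2 to compound 3 (within the scatter) did the same. Compound 4 `c1coc(CNCCCNc2ccnc3cc(CC4CCCCC4)ccc23)c1` differs from compound 1 at another place: cyclohexylmethyl in place of 3-(dimethylamino)phenoxy on an aromatic carbon. Within the data shown here, none of the measured steps touches this position, so no measured step bears on the change. The estimate for compound 4 in this assay is therefore uncertain; compound 4 is expected to give 8000 nM, within 2000 nM to 20000 nM, which means an expected step of a 1.8-fold lower number from compound 1 to compound 4 (0.26 log units; within the scatter).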

Compound 4, solubility: 4200 nM
The estimate for compound 4 lay 1.9-fold (0.28 log units) above the measured number; the measured number falls inside the stated range.
By their numbers in this assay, from the lowest: compound 4; then compounds 1, 2 and 3 (each within the scatter of the next).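

Replacing 3-(dimethylamino)phenoxy with cyclohexylmethyl on this aromatic carbon gives a 3.5-fold lower number from compound 1 to compound 4 (0.54 log units; beyond the scatter) in this assay and is the first step shown to lie beyond the scatter. The earlier compounds shown here varied only the group on the saturated chain carbon bound to an amine nitrogen, and their values stayed level. No evidence given here accounts for this step.

As far as these compounds go, the two groups differ in several parts at once, so it remains open which part goes with the step. A phenoxy or cyclohexyloxy group at this position would separate those parts.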